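Swapping fluoro for chloro on the cinnamoyl ring

The compounds below may be only part of what the source reports. "The series", "measured", "known", "first", "only" and "open" are said of these compounds alone.

Compound 1 `O=C(/C=C/c1ccc(F)c(Cl)c1)c1ccc(B(O)O)cc1` gives 8500 nM.
Compound 2 `O=C(/C=C/c1ccc(F)c(Br)c1)c1ccc(B(O)O)cc1` gives 9500 nM.

In a functional assay on MDA-MB-231 cells (Homo sapiens) for inhibition (on this read-out higher numbers stand for weaker inhibition and lower numbers for stronger inhibition), compound 1 has the lowest of the two numbers, but its nearest neighbour compound 2 is close: the step of a 1.1-fold higher number from compound 1 to compound 2 (0.05 log units; within the scatter) lies within the scatter, so the two compounds cannot be ranked against each other. Compound 3 `O=C(/C=C/c1ccc(Cl)c(Cl)c1)c1ccc(B(O)O)cc1` has not yet been measured. It differs from compound 1 by chloro in place of fluoro on an aromatic carbon. Within the data shown here, no measured pair shows this particular exchange. Among the measured compounds shown here, the only step that bears on it is the halogen exchange at the neighbouring position, a 1.1-fold higher number from compound 1 to compound 2 (0.05 log units; within the scatter), which was within the scatter. On that basis compound 3 is expected to stay close to compound 1, with no step beyond the scatter, and its estimated step is no change at the digits printed from compound 1 to compound 3 (within the scatter). The value of compound 3 is estimated at 8500 nM, with a range of 4000 nM to 18000 nM.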

Compound 3, half-maximal inhibitory concentration: 9500 nM
Beside the measured number, compound 3's estimate is 1.1-fold (0.05 log units) below it, and the stated range covers the measured number.
By their numbers in this assay, from the lowest: compounds 1, 2 and 3 (each within the scatter of the next).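

In this assay, the carbon para to a large group and ortho to a chloro group now has a measured exchange of its own: chloro in place of fluoro gives a 1.1-fold higher number from compound 1 to compound 3 (0.05 log units; within the scatter). The earlier step, a 1.1-fold higher number from compound 1 to compound 2 (0.05 log units; within the scatter), concerned only the halogen at the other substituted carbon, so it said nothing directly about this position. Together, the two steps show that fluoro and chloro cannot be told apart at this carbon, and that neither halogen exchange shown moves the number beyond the scatter. No measurement offers an explanation for this result.

From the compounds shown here alone, it remains open whether an amine, a carboxylic acid or a methoxy group on this carbon would leave the number as it is. The compounds also leave open whether removing the halogen altogether, leaving hydrogen there, would produce a step beyond the scatter.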